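From phenoxy to vinyl on the shared core

A few compounds are considered here, and "the series" means these few. Any claim that something is new, unique, unknown or untested is made for them only; others in the source may bear on it.

In a functional assay on MCF7 cells (Homo sapiens) for inhibition, read by resazurin assay, with a stated time of 72 h (a lower number here means a stronger inhibitor, a higher number a weaker inhibitor), compound 1 (`COc1ccc(C2C(O)C(=O)N2c2cc(OC)c(OC)c(OC)c2)cc1`) gives 4 nM, compound 2 (`C=CC1C(=O)N(c2cc(OC)c(OC)c(OC)c2)C1c1ccc(SC)cc1`) gives 51 nM and compound 3 (`COc1ccc(C2C(Oc3ccccc3)C(=O)N2c2cc(OC)c(OC)c(OC)c2)cc1`) gives 23 nM. Compound 3 thus holds the second highest of the three numbers, above compound 1 and below compound 2.

Compound 4 (`C=CC1C(=O)N(c2cc(OC)c(OC)c(OC)c2)C1c1ccc(OC)cc1`) has vinyl in place of phenoxy on a saturated ring carbon. Within the data shown here, one measured step bears on this place, namely a 5.8-fold higher number from compound 1 to compound 3 (0.76 log units; beyond the scatter), a modest step beyond the scatter, with phenyl in place of hydrogen on an oxygen on a saturated carbon. It shows that a change here can move the number, but it does not test vinyl. Of the measured compounds, only compound 2 carries vinyl, and it gives 51 nM, yet it also differs from compound 4 elsewhere in the structure. No direct comparison of vinyl with phenoxy has been measured, so the estimate remains loose.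

No step beyond the scatter is expected in this assay, and the expected step is a 1.3-fold higher number from compound 3 to compound 4 (0.12 log units; within the scatter). Compound 4 is estimated at 30 nM, with an expected range from 10 nM to 90 nM.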

Compound 4, half-maximal inhibitory concentration: 17 nM
For compound 4 the middle estimate is 1.8-fold (0.25 log units) above the measured one; the range from low to high includes it.
By their numbers in this assay, from the lowest: compound 1; then compounds 4 and 3 (each within the scatter of the next); then compound 2.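

In this assay, among these compounds, the direct comparison at this saturated ring carbon shows a 1.4-fold lower number from compound 3 to compound 4 (0.13 log units; within the scatter) for vinyl in place of phenoxy, so the two groups cannot be told apart here, although vinyl has far fewer heavy atoms and no ring, while vinyl in place of hydroxy gives a 4.3-fold higher number from compound 1 to compound 4 (0.63 log units; beyond the scatter), which leaves hydroxy the one group at this place with a number set apart from vinyl. With vinyl held constant, methoxy in place of methylsulfanyl on an aromatic carbon gives a 3.0-fold lower number from compound 2 to compound 4 (0.48 log units; beyond the scatter), so the number of compound 2 cannot be read as the number for vinyl on the core of compound 4, and the other place also moves the result. Nothing in the data available here accounts for any of these steps.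

The compounds shown leave open how an amine or a longer chain on this ring carbon would compare with hydroxy, phenoxy and vinyl. They also leave open whether the step from methylsulfanyl to methoxy is of similar size when hydroxy or phenoxy, rather than vinyl, sits on the ring carbon.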